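This account rests on a few compounds, and the source may have more. Where it says the series, first, only, none or still open, it means among the compounds named here.

Measured compounds in a functional assay on MCF7 cells (Homo sapiens) for cytotoxicity, read by MTT assay, with a stated time of 72 h; a higher number here means a weaker inhibitor, a lower number a stronger inhibitor: compound 1, `COc1c(OCCCCN2CCN(C)CC2)cc(O)c2c(=O)cc(-c3ccc(Cl)cc3)oc12`, gives 3210 nM; compound 2, `COc1c(OCCCCN2CCN(C)CC2)cc(O)c2c(=O)cc(-c3ccc([N+](=O)[O-])cc3)oc12`, gives 4090 nM; compound 3, `COc1ccccc1-c1cc(=O)c2c(O)cc(OCCCCN3CCN(C)CC3)c(OC)c2o1`, gives 5430 nM.

The three numbers sit close together. The steps of a 1.3-fold higher number from compound 1 to compound 2 (0.11 log units; within the scatter), a 1.7-fold higher number from compound 1 to compound 3 (0.23 log units; within the scatter) and a 1.3-fold higher number from compound 2 to compound 3 (0.12 log units; within the scatter) all fall within the scatter, so compound 3 is not separated from compound 1 or compound 2 on these data.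

Compound 4, `COc1c(OCCCCN2CCN(C)CC2)cc(O)c2c(=O)cc(-c3ccc(F)cc3Br)oc12`, arises from compound 3 by 2-bromo-4-fluorophenyl in place of 2-methoxyphenyl on an aromatic carbon. Among the compounds with values here, the only steps that bear on it are the three aryl exchanges on the same carbon, each within the scatter, and nothing in them points to a shift beyond the scatter in this assay. The step is expected to be a 1.4-fold lower number from compound 3 to compound 4 (0.13 log units; within the scatter). Compound 4 is therefore estimated at 4000 nM, with a range from 1800 nM to 9000 nM.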

Compound 4, half-maximal inhibitory concentration: 3090 nM
Compound 4: the middle estimate sits 1.3-fold (0.11 log units) above what was measured; the range from low to high includes it.
By their numbers in this assay, from the lowest: compounds 4, 1, 2 and 3 (each within the scatter of the next).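

In this assay the 2-bromo-4-fluorophenyl group, on the aromatic carbon next to the ring oxygen, stays within the scatter of the 2-methoxyphenyl (a 1.8-fold lower number from compound 3 to compound 4 (0.24 log units; within the scatter)), 4-nitrophenyl (a 1.3-fold lower number from compound 2 to compound 4 (0.12 log units; within the scatter)) and 4-chlorophenyl (a 1.0-fold lower number from compound 1 to compound 4 (0.02 log units; within the scatter)) compounds. A ring carrying both bromine and fluorine therefore joins the aryl groups that cannot be separated at this position. No independent measurement offers an explanation for these values.

Still open, as far as these compounds go, is whether an amine or a carboxylic acid on this aryl ring would move the value beyond the scatter. The same question holds for a saturated ring at this carbon.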